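The source may hold more compounds than are shown below. What is called first, only, known or untested is meant among the compounds shown, and "the series" means these compounds.

For the measured compounds named here, compound 2 `CCC1CCCCN1C[C@@H](O)CNS(=O)(=O)c1cccc2ccccc12` stands at the higher of the two single numbers so far in an assay on HEK293 cells for inhibition of sodium- and chloride-dependent glycine transporter 1 (Homo sapiens) (a lower number here means a stronger inhibitor, a higher number a weaker inhibitor), where compound 2 gives 7940 nM. Its nearest neighbour is compound 1 `O=S(=O)(NC[C@H](O)CN1CCCC1)c1cccc2ccccc12`, which in this assay gives 3160 nM; the two are separated by a 2.5-fold higher number from compound 1 to compound 2 (0.40 log units; beyond the scatter). Compound 3 `CC(C)C1CCCN1C[C@@H](O)CNS(=O)(=O)c1cccc2ccccc12` has no single number, since in this assay compound 3 gives 200 nM; 1000 nM (2 entries), as recorded in the several entries of compound 3 in this assay, 200 nM; 1000 nM (2 entries).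

Compound 4 `O=S(=O)(NC[C@H](O)CN1CCCCC1)c1cccc2ccccc12` differs from compound 2 by hydrogen in place of ethyl on a saturated ring carbon: the ethyl on a saturated ring carbon of the six-membered non-aromatic ring with 1 nitrogen gives way to hydrogen, so that 2-ethylpiperidin-1-yl becomes piperidin-1-yl. Going by the values given here, the only measured step that bears on this is a 2.5-fold higher number from compound 1 to compound 2 (0.40 log units; beyond the scatter), which brought in the ethyl together with a change of ring size; the present change removes only the ethyl. A modest lowering of the number, of about that size and possibly not clearing the scatter, is therefore expected: a 2.3-fold lower number from compound 2 to compound 4 (0.36 log units; beyond the scatter). For compound 4 the expected value in this assay is estimated at 3500 nM, within a range from 1200 nM to 10000 nM.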

Compound 4, half-maximal inhibitory concentration: 3160 nM
Compound 4: the middle estimate sits 1.1-fold (0.04 log units) above what was measured; the measured number falls inside the stated range.
By their numbers in this assay, from the lowest: compounds 1 and 4 (each within the scatter of the next); then compound 2.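

Taken alone, the loss of the ethyl next to the ring nitrogen lowers the number (in this assay, a 2.5-fold lower number from compound 2 to compound 4 (0.40 log units; beyond the scatter)), so the ethyl on this saturated ring carbon carries a measurable cost. The ring change alone leaves the number unmoved (no change at the digits printed from compound 1 to compound 4 (within the scatter)), which separates the two changes combined in the earlier step and places that step's rise with the ethyl rather than with the move from pyrrolidin-1-yl to piperidin-1-yl. Nothing at hand gives a reason for either step.

From the compounds shown here alone, whether a methyl, a longer chain or an amine in place of the ethyl would raise the number to the same degree remains open. Compound 3 has no single number, so its steps to the other compounds cannot be read: the several entries of compound 3 in this assay, 200 nM; 1000 nM (2 entries).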